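Chlorophenyl placement on the sulfur-linked benzyl: working notes

This account rests on a few compounds, and the source may have more. Where it says the series, first, only, none or still open, it means among the compounds named here.

Measured so far:
compound 1 `Cc1cc(-c2ccccc2)n(/C(N)=N/S(=O)(=O)c2cc(C)c(Cl)cc2SCc2cccc3ccccc23)n1`: 12000 nM
compound 2 `Cc1cc(-c2ccccc2)n(/C(N)=N/S(=O)(=O)c2cc(C)c(Cl)cc2SCc2cccc(Cl)c2)n1`: 18000 nM

Both compounds were run in an ADME assay on HaCaT cells (Homo sapiens) for cytotoxicity, read by MTT assay, with a stated time of 72 h; a higher number here means a weaker inhibitor, a lower number a stronger inhibitor. There compound 1 gives 12000 nM and compound 2 gives 18000 nM. For the measured compounds named here, the one measured step, a 1.5-fold higher number from compound 1 to compound 2 (0.18 log units; within the scatter), stays within the scatter. Compound 2 therefore holds the higher of the two numbers only nominally; no order between compound 1 and compound 2 can be read from these values.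

Compound 3 `Cc1cc(-c2ccccc2)n(/C(N)=N/S(=O)(=O)c2cc(C)c(Cl)cc2SCc2ccc(Cl)cc2)n1` is the next member. It differs from compound 2 by 4-chlorophenyl in place of 3-chlorophenyl on a saturated chain carbon bound to a sulfur. Going by the values given here, the only measured step at this position, a 1.5-fold higher number from compound 1 to compound 2 (0.18 log units; within the scatter), replaced a larger group with the 3-chlorophenyl and produced nothing beyond the scatter. The change now considered keeps the same atoms and only moves the chlorine on the ring, so on this evidence no step beyond the scatter is expected in this assay, in either direction. For compound 3 the estimate in this assay is 16000 nM, with a range of 7000 nM to 36000 nM, which corresponds to an expected step of a 1.1-fold lower number from compound 2 to compound 3 (0.05 log units; within the scatter).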

Compound 3, half-maximal inhibitory concentration: 11000 nM
Compound 3: the middle estimate sits 1.5-fold (0.16 log units) above what was measured; low and high end bracket the measured number.
By their numbers in this assay, from the lowest: compounds 3, 1 and 2 (each within the scatter of the next).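

Moving the chlorine, with 4-chlorophenyl in place of 3-chlorophenyl on a saturated chain carbon bound to a sulfur, gives in this assay a 1.6-fold lower number from compound 2 to compound 3 (0.21 log units; within the scatter), so a change that keeps the same atoms and only rearranges them leaves no readable difference at this position. The bicyclic group and the second chlorinated ring can now also be compared directly: 4-chlorophenyl in place of naphthalen-1-yl gives a 1.1-fold lower number from compound 1 to compound 3 (0.04 log units; within the scatter), and taken with the earlier step, all three groups on this carbon lie within the scatter of one another, with no order among them. Nothing available bears on why these numbers stay so close, and the series offers no explanation for it.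

Still open, on these data alone, is whether a group of a different kind on the benzyl ring, such as an amine or a carboxylic acid, or a longer chain between the sulfur and the ring, would give a step beyond the scatter. All three compounds share one core and differ only in the aryl group, so they also leave open how far the number depends on the rest of the molecule.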